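The source may hold more compounds than are shown below. What is called first, only, known or untested is meant among the compounds shown, and "the series" means these compounds.

Of the compounds shown here, two have been measured so far. In a functional assay (aorta) with Rattus norvegicus as the target (a higher number here means that more compound is needed for the effect, a lower number that less compound is needed), compound 1 `O=C1CCCCN1C1=CC(CF)(CF)Oc2ccc([N+](=O)[O-])cc21` gives 17.4 nM and compound 2 `N#Cc1ccc2c(c1)C(n1ccccc1=O)=CC(CF)(CF)O2` gives 24.6 nM. These two numbers lie within the usual scatter of each other, so compound 2 cannot be placed ahead of or behind compound 1.

The next compound, compound 3 `O=c1ccccn1C1=CC(CF)(CF)Oc2ccc([N+](=O)[O-])cc21`, keeps the rest of compound 2 but has nitro in place of cyano on an aromatic carbon. Nitro is also the group that compound 1 carries at this place. For the measured compounds named here, no measured pair differs by this one change alone, so its size has not been seen directly. The nearest evidence is indirect: compound 1, with nitro, gives 17.4 nM, and compound 2, with cyano, gives 24.6 nM, even though these two also differ elsewhere in their structures. On that basis, the step of a 1.4-fold lower number from compound 2 to compound 3 (0.14 log units; within the scatter) is expected to stay within the scatter, with no clear direction. The estimated value for compound 3 is 18 nM, with an expected range from 6 nM to 55 nM.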

Compound 3, half-maximal effective concentration: 2.46 nM
The estimate for compound 3 lay 7.3-fold (0.86 log units) above the measured number; measured number outside the range, below it.
By their numbers in this assay, from the lowest: compound 3; then compounds 1 and 2 (each within the scatter of the next).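

In this assay, for the compounds shown here, nitro in place of cyano on the aromatic carbon gives a 10-fold lower number from compound 2 to compound 3 (1.00 log units; beyond the scatter), with the rest of the structure unchanged, so this is the first direct sign that the group at this place matters. The other place matters as well: with nitro kept, the group containing a six-membered aromatic ring in place of the one containing a six-membered non-aromatic ring, on the double-bonded ring carbon, gives a 7.1-fold lower number from compound 1 to compound 3 (0.85 log units; beyond the scatter), a step that the earlier pair, differing in both places at once, could not show on its own. No measurement at hand offers a reason for either step.

The compounds shown leave open whether the nitro-for-cyano step would keep its size with the non-aromatic ring group in place, since the comparison so far rests on the aromatic ring group alone. They also leave open whether a different group on the aromatic carbon, such as an amine or a carboxylic acid, would give a number as low as that of compound 3 or a lower one.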